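Swapping a hexenyl chain for a methylcyclopropylmethyl group

A few compounds are considered here, and "the series" means these few. Any claim that something is new, unique, unknown or untested is made for them only; others in the source may bear on it.

Two compounds share the same core and differ only in the chain bound to the oxygen on an aromatic ring. Compound 1 `CCOc1cc(CCc2nc(C)c(CC)s2)nc(NCc2cc(Cl)cc(NC(=O)OC(C)C)c2)c1` gives 33 nM in an assay on cells for binding affinity to Neuropeptide Y receptor type 1 (Homo sapiens); a lower number here means a stronger inhibitor, a higher number a weaker inhibitor. Compound 2 `CC/C=C\CCOc1cc(CCc2nc(C)c(CC)s2)nc(NCc2cc(Cl)cc(NC(=O)OC(C)C)c2)c1` gives 4.7 nM and stands as the lower of the two numbers, with the step of a 7.0-fold lower number from compound 1 to compound 2 (0.85 log units; beyond the scatter) lying beyond the scatter. Compound 3 `CCc1sc(CCc2cc(OCC3(C)CC3)cc(NCc3cc(Cl)cc(NC(=O)OC(C)C)c3)n2)nc1C` is not yet measured; it differs from compound 2 by 1-methylcyclopropyl in place of pent-2-en-1-yl on a saturated chain carbon bound to an oxygen on an aromatic ring. Among the measured compounds shown here, the only step available, from compound 1 to compound 2, shows that lengthening the chain from ethyl to hexenyl lowered the number in this assay. The new group in compound 3 is smaller than the hexenyl chain of compound 2 but larger than the ethyl of compound 1, so a modest rise in the number is expected. Compound 3 is therefore estimated at 12 nM, within 4 nM to 35 nM, which means an expected step of a 2.6-fold higher number from compound 2 to compound 3 (0.41 log units; beyond the scatter).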

Compound 3, half-maximal inhibitory concentration: 17 nM
Estimate against measurement, compound 3: 1.4-fold (0.15 log units) below; low and high end bracket the measured number.
By their numbers in this assay, from the lowest: compound 2; then compounds 3 and 1 (each within the scatter of the next).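

In this assay, replacing the hex-3-en-1-yl chain with (1-methylcyclopropyl)methyl gives a 3.6-fold higher number from compound 2 to compound 3 (0.56 log units; beyond the scatter) at this position on the oxygen, so the gain seen with the hexenyl chain does not carry over to every group that replaces ethyl. Set against the ethyl group of compound 1, the new group gives a 1.9-fold lower number from compound 1 to compound 3 (0.29 log units; within the scatter) and cannot be told apart from it. Of the two replacements for ethyl shown here, only the hex-3-en-1-yl chain stands clearly apart from compound 1.

From the compounds shown here alone, it remains open whether a saturated hexyl chain, without the double bond, would give a number close to that of compound 2. The effect of a terminal amine or a carboxylic acid on such a chain is also unknown. No measurement here explains why these groups differ.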